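Swapping the aryl ether arm for phenethyl

This account rests on a few compounds, and the source may have more. Where it says the series, first, only, none or still open, it means among the compounds named here.

Compound 1 `c1ccc(CCc2ccc3c(NCCCNCc4ccco4)ccnc3c2)cc1`: 16000 nM
Compound 2 `COc1ccccc1Oc1ccc2c(NCCCNCc3ccco3)ccnc2c1`: 6500 nM
Compound 3 `COc1ccc(F)cc1CNCCCNc1ccnc2cc(Oc3ccccc3OC)ccc12`: 6400 nM

All three were tested in an ADME assay on HepG2 cells (Homo sapiens) for cytotoxicity, read by luminescence, CellTiter-Glo and ATP content, with a stated time of 72 h; on this read-out higher numbers stand for an effect only at larger amounts of compound and lower numbers for an effect already at smaller amounts. Compound 2 differs from compound 1 in one place, (phenethyl in place of 2-methoxyphenoxy on an aromatic carbon), and this gave a 2.5-fold higher number from compound 2 to compound 1 (0.39 log units; beyond the scatter). Compound 3 differs from compound 2 in another place, (5-fluoro-2-methoxyphenyl in place of furan-2-yl on a saturated chain carbon bound to an amine nitrogen), and here the numbers barely moved: a 1.0-fold lower number from compound 2 to compound 3 (0.01 log units; within the scatter). Compound 4 `COc1ccc(F)cc1CNCCCNc1ccnc2cc(CCc3ccccc3)ccc12` is not yet measured; it carries the same change relative to compound 3 that compound 1 carries relative to compound 2, namely (phenethyl in place of 2-methoxyphenoxy on an aromatic carbon). The place of the change is described in the same words for both pairs, so the change is the same, only the core on which it sits differs as described above. Since compound 3 and compound 2 lie within the scatter of each other, the earlier step is the best guide, and for compound 4 a step of about a 2.3-fold higher number from compound 3 to compound 4 (0.37 log units; beyond the scatter) is expected because a 2.5-fold higher number from compound 2 to compound 1 (0.39 log units; beyond the scatter). Compound 4 is therefore estimated at 15000 nM, with a range from 7000 nM to 32000 nM.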

Compound 4, half-maximal effective concentration: 4240 nM
For compound 4 the middle estimate is 3.5-fold (0.55 log units) above the measured one; the measured number lies below the stated range.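

In this assay, phenethyl in place of 2-methoxyphenoxy gives a 1.5-fold lower number from compound 3 to compound 4 (0.18 log units; within the scatter), so the swap does not repeat on the second core what it did on the first: the same change on two cores in this assay, a 2.5-fold higher number (0.39 log units; beyond the scatter) from compound 2 to compound 1 and a 1.5-fold lower number (0.18 log units; within the scatter) from compound 3 to compound 4, 3.7-fold (0.57 log units) apart, beyond the scatter of two such steps. Read the other way, 5-fluoro-2-methoxyphenyl in place of furan-2-yl gives a 3.8-fold lower number from compound 1 to compound 4 (0.58 log units; beyond the scatter) with phenethyl on the aromatic carbon, whereas with 2-methoxyphenoxy there it left the numbers within the scatter: the same change on two cores in this assay, a 1.0-fold lower number (0.01 log units; within the scatter) from compound 2 to compound 3 and a 3.8-fold lower number (0.58 log units; beyond the scatter) from compound 1 to compound 4, 3.7-fold (0.57 log units) apart, beyond the scatter of two such steps. In these four compounds, then, the two changes do not simply add up, and a step seen on one core cannot be carried unchanged to another, but this single set of four compounds does not show why this happens or whether it holds elsewhere in the series.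

The compounds shown leave open whether other groups on the aromatic carbon, such as a morpholine or a carboxylic acid, would behave in the same way. They also leave open what a longer chain in place of the saturated chain bearing the amine nitrogens would do.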